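A few compounds are considered here, and "the series" means these few. Any claim that something is new, unique, unknown or untested is made for them only; others in the source may bear on it.

Compound 1 `Cc1cc(O)c(C2=NN(c3ccc(S(N)(=O)=O)cc3)C(c3ccccc3Cl)C2)cc1Cl` gives 14000 nM in a functional assay on IGROV-1 cells (Homo sapiens) for antiproliferative activity, with a stated time of 48 h; on this read-out lower numbers stand for stronger inhibition of growth and higher numbers for weaker inhibition of growth. Compound 2 `Cc1cc(O)c(C2=NN(c3ccc(S(N)(=O)=O)cc3)C(/C=C/c3ccccc3)C2)cc1Cl` gives 19800 nM in this assay.

Compound 2 stands alongside compound 1 in this assay: the step of a 1.4-fold higher number from compound 1 to compound 2 (0.15 log units; within the scatter) falls within the scatter, so the two numbers cannot be told apart. Compound 3 `COc1ccc(C2CC(c3cc(Cl)c(C)cc3O)=NN2c2ccc(S(N)(=O)=O)cc2)cc1OC` differs from compound 2 by 3,4-dimethoxyphenyl in place of 2-phenylethenyl on a saturated ring carbon. For the measured compounds named here, only one measured step touches this saturated ring carbon, a 1.4-fold higher number from compound 1 to compound 2 (0.15 log units; within the scatter), and it stayed within the scatter when one ring-bearing group replaced another there. No step beyond the scatter is therefore expected for this assay, a 1.2-fold lower number from compound 2 to compound 3 (0.09 log units; within the scatter). Compound 3 is estimated at 16000 nM, with a range from 6000 nM to 45000 nM.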

Compound 3, concentration for total growth inhibition: 5460 nM
Compound 3: the middle estimate sits 2.9-fold (0.47 log units) above what was measured, outside the stated range (below it).
By their numbers in this assay, from the lowest: compound 3; then compounds 1 and 2 (each within the scatter of the next).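

On this saturated ring carbon, the group can change the number in this assay beyond the scatter: 3,4-dimethoxyphenyl gives a 3.6-fold lower number from compound 2 to compound 3 (0.56 log units; beyond the scatter) and also a 2.6-fold lower number from compound 1 to compound 3 (0.41 log units; beyond the scatter), both modest steps. The earlier swap of 2-chlorophenyl for 2-phenylethenyl had shown no such change. Nothing available here explains this difference. As far as these compounds go, it remains open whether both methoxy groups are needed or a single one, as in 4-methoxyphenyl, would give the same number. Also open, from the compounds shown here alone, is how a phenyl ring carrying an amine or a carboxylic acid would behave at this position.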